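Swapping chloro for cyano on a shared acetylene-linked core

The compounds below may be only part of what the source reports. "The series", "measured", "known", "first", "only" and "open" are said of these compounds alone.

Measured so far, in an assay on CHO cells for displacement of a labelled ligand from prostaglandin D2 receptor 2 (Homo sapiens), read by scintillation counting; a lower number here means a stronger inhibitor, a higher number a weaker inhibitor:
compound 1 `CCCS(=O)(=O)c1ccc(C)c(C#Cc2cc(C#N)ccc2OCC(=O)O)c1` gives 7 nM;
compound 2 `CCCS(=O)(=O)c1cccc(C#Cc2cc(Cl)ccc2OCC(=O)O)c1` gives 9 nM;
compound 3 `O=C(O)COc1ccc(Cl)cc1C#Cc1cccc(C(F)(F)F)c1` gives 92 nM.

Compound 2 stands second highest of these three numbers. Its nearest neighbour is compound 1, within the scatter, and its furthest is compound 3, reached by a 10-fold higher number from compound 2 to compound 3 (1.01 log units; beyond the scatter), a change at the sulfonyl end of the molecule.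

The new compound 4 `CCCS(=O)(=O)c1cccc(C#Cc2cc(C#N)ccc2OCC(=O)O)c1` differs from compound 2 only in this: cyano in place of chloro on an aromatic carbon, a change para to a carboxymethoxy group. Among the compounds with values here, no measured step tests exactly this swap. Within the data shown here, the one step known, from compound 2 to compound 3, concerns another part of the molecule and so does not bear on it. Compound 1 does carry a cyano at the same position, though with a methyl elsewhere as well, and its value and that of compound 2 sit within the scatter of each other. On this basis no step beyond the scatter is expected for a 1.3-fold lower number from compound 2 to compound 4 (0.11 log units; within the scatter). Compound 4 is therefore estimated at 7 nM, in the range 3 nM to 16 nM.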

Compound 4, inhibition constant: 21 nM
Compound 4: the middle estimate sits 3.0-fold (0.48 log units) below what was measured; the whole stated range lies below it.
By their numbers in this assay, from the lowest: compounds 1 and 2 (each within the scatter of the next); then compound 4; then compound 3.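

In this assay, the position para to a carboxymethoxy group responds to the swap of groups: cyano in place of chloro brings a 2.3-fold higher number from compound 2 to compound 4 (0.37 log units; beyond the scatter). With cyano present, the methyl elsewhere on the molecule also matters, since hydrogen in place of methyl brings a 3.0-fold higher number from compound 1 to compound 4 (0.48 log units; beyond the scatter). Nothing measured here explains either step.

The compounds shown leave open whether the methyl would count as much with chloro in the cyano position. Going by these compounds, how this position would respond to other groups, such as an amine or a methoxy group, also remains open.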